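From a pentyl chain to a 4-methylpiperazin-1-yl group

The source may hold more compounds than are shown below. What is called first, only, known or untested is meant among the compounds shown, and "the series" means these compounds.

In a functional assay on MCF7 cells (Homo sapiens) for inhibition, read by MTT assay, with a stated time of 72 h (on this read-out higher numbers stand for weaker inhibition and lower numbers for stronger inhibition), compound 1 (`Cc1ccc(NC(=O)C2CCN(C/C=C/c3ccccc3)CC2)cc1`) gives 30000 nM and compound 2 (`CC(C)c1ccc(NC(=O)C2CCN(C/C=C/c3ccccc3)CC2)cc1`) gives 9100 nM while compound 3 (`CCCCCc1ccc(NC(=O)C2CCN(C/C=C/c3ccccc3)CC2)cc1`) gives 3740 nM as the lowest number of the three. Methyl to isopropyl brought a 3.3-fold lower number from compound 1 to compound 2 (0.52 log units; beyond the scatter) and isopropyl to pentyl brought a 2.4-fold lower number from compound 2 to compound 3 (0.39 log units; beyond the scatter) as the alkyl group grew. Compound 4 (`CN1CCN(c2ccc(NC(=O)C3CCN(C/C=C/c4ccccc4)CC3)cc2)CC1`) carries 4-methylpiperazin-1-yl in place of pentyl on an aromatic carbon. Within the data shown here, no measured compound has a ring at this place, so these modest steps guide the size of the change only loosely. In this assay a modest step is expected, namely a 2.1-fold higher number from compound 3 to compound 4 (0.33 log units; beyond the scatter) toward weaker inhibition. For compound 4 the estimated value is 8000 nM (range 2000 nM to 30000 nM).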

Compound 4, half-maximal inhibitory concentration: 44000 nM
The estimate for compound 4 lay 5.5-fold (0.74 log units) below the measured number; the measured number lies above the stated range.
By their numbers in this assay, from the lowest: compound 3; then compound 2; then compounds 1 and 4 (each within the scatter of the next).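

In this assay, 4-methylpiperazin-1-yl gives up the gain made along the alkyl groups, with a 12-fold higher number from compound 3 to compound 4 (1.07 log units; beyond the scatter) and a 4.8-fold higher number from compound 2 to compound 4 (0.68 log units; beyond the scatter), while a 1.5-fold higher number from compound 1 to compound 4 (0.17 log units; within the scatter) leaves it level with the methyl group. Growth at this position therefore does not lower the number in every case: this larger group, with its ring and two nitrogens, goes against the trend from methyl to pentyl. Nothing available explains this reversal.

As far as these compounds go, whether the ring or its nitrogens matter remains open. A cyclohexyl group or a chain longer than pentyl would help to separate these possibilities.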